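This account rests on a few compounds, and the source may have more. Where it says the series, first, only, none or still open, it means among the compounds named here.

Of the compounds shown here, three sharing one core have been measured in a functional assay on PANC-1 cells (Homo sapiens) for cytotoxicity, read by MTT assay, with a stated time of 72 h, tested at 1 uM; on this read-out higher numbers stand for a weaker effect at the one concentration tested and lower numbers for a stronger effect. Compound 1, `C=C1C(=O)O[C@@H](c2ccc(OC)cc2)[C@H]1C`, gives 130%. Compound 2, `C=C1C(=O)O[C@@H](c2ccccc2)[C@H]1c1ccccc1`, gives 108%, and compound 3, `C=C1C(=O)O[C@H](c2ccccc2)[C@H]1c1ccccc1`, gives 116%. Compound 3 therefore stands second highest of the three numbers. Its nearest neighbour is compound 2, and the change a number 8 percentage points higher from compound 2 to compound 3 (within the scatter) stays within the scatter, which fits (the fact that compounds 2 and 3 differ only in the configuration as drawn). Compound 1 lies furthest from compound 3, its number higher by a gap beyond the scatter.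

Compound 4, `C=C1C(=O)O[C@H](c2ccc(OC)cc2)[C@H]1c1ccccc1`, has not yet been measured. It differs from compound 3 by methoxy in place of hydrogen on an aromatic carbon. Among the measured compounds shown here, none of the measured steps involves the entry of a methoxy group; the single measured step, that between compounds 2 and 3, concerns configuration alone and stayed within the scatter, so it offers no guide to the size of this change. For the measured compounds named here, the only hint comes from compound 1, which also carries a methoxy on an aromatic ring and reads higher than compound 3. The step of a number 4 percentage points higher from compound 3 to compound 4 (within the scatter) is therefore expected to be small, leaning upward if anywhere, and not clearly beyond the scatter. Compound 4 is estimated at 120%, within a range from 100% to 140%.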

Compound 4, a percentage reported as activity, at one concentration (the size of the read-out at that concentration, not a potency): 80%
Compound 4: the middle estimate sits 40 percentage points above what was measured; the whole stated range lies above it.
By their numbers in this assay, from the lowest: compound 4; then compounds 2 and 3 (each within the scatter of the next); then compound 1.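

Among the compounds shown here, the entry of methoxy in place of hydrogen on an aromatic carbon, para to a large group, is the first single change that moves the read-out beyond the scatter: in this assay the result is a number 36 percentage points lower from compound 3 to compound 4 (beyond the scatter), which stands for a stronger effect at the one concentration tested. For the compounds shown here, this aromatic position therefore responds to substitution on the background of compound 3, whereas the only earlier step, a change in configuration as drawn, stayed within the scatter and gave no sign that the read-out could shift this far. Nothing among the compounds shown accounts for the size of this step.

From the compounds shown here alone, it remains open whether the same methoxy change would have a similar effect in the configuration of compound 2, since this step has been read in only one stereochemical setting. Going by these compounds, it is equally open whether an ethoxy group, a hydroxyl group, a chlorine atom or an amine on the same aromatic carbon would shift the number as far, or whether the effect is particular to methoxy.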